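A few compounds are considered here, and "the series" means these few. Any claim that something is new, unique, unknown or untested is made for them only; others in the source may bear on it.

Going by the values given here, in a functional assay on A549 cells (Homo sapiens) for antiproliferative activity, read by MTT assay, with a stated time of 48 h (a higher number here means a weaker inhibitor, a lower number a stronger inhibitor), compound 1 (`CCOc1cc(-c2ccc3c(ccn3C)c2)cn2c(-c3cc(OC)c(OC)c(OC)c3)nnc12`) gives 334 nM and compound 2 (`COc1cc(-c2nnc3c(OC4COC4)cc(-c4ccc5c(ccn5C)c4)cn23)cc(OC)c1OC`) gives 516 nM within the scatter of compound 1, so compound 2 stands level with the only other measured number. The next change leads to compound 3 (`COc1cc(-c2nnc3c(OC4CC4)cc(-c4ccc5c(ccn5C)c4)cn23)cc(OC)c1OC`), with cyclopropyl in place of oxetan-3-yl on an oxygen on an aromatic ring. Among the compounds with values here, one measured step bears on it: a 1.5-fold higher number from compound 1 to compound 2 (0.19 log units; within the scatter) for oxetan-3-yl in place of ethyl on that oxygen, and it stays inside the scatter. Within the data shown here, with only that step to go on, no shift beyond the scatter is expected in this assay for compound 3, and the data give no firm direction. The estimated step is a 1.4-fold lower number from compound 2 to compound 3 (0.13 log units; within the scatter) and nothing larger is expected. For compound 3 the estimate is 380 nM with an expected range of 150 nM to 950 nM around it.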

Compound 3, half-maximal inhibitory concentration: 168 nM
Estimate against measurement, compound 3: 2.3-fold (0.35 log units) above, and the stated range covers the measured number.
By their numbers in this assay, from the lowest: compounds 3, 1 and 2 (each within the scatter of the next, the first and the last beyond it).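

Going by these compounds alone, at the oxygen on an aromatic ring, cyclopropyl in place of oxetan-3-yl gives the first step that lies beyond the scatter in this assay (a 3.1-fold lower number from compound 2 to compound 3 (0.49 log units; beyond the scatter)). Cyclopropyl in place of ethyl stays inside the scatter (a 2.0-fold lower number from compound 1 to compound 3 (0.30 log units; within the scatter)), as did the earlier exchange of ethyl for oxetan-3-yl, so the position separates only the cyclopropyl and oxetan-3-yl compounds, and the step is modest. Nothing measured here accounts for the difference between these two groups.

The compounds shown leave open how a longer chain, such as n-butyl, or a chain ending in an amine would read on this oxygen in this assay. As far as these compounds go, whether the exchange of oxetan-3-yl for cyclopropyl gives a similar step on a different core also remains open.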